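Two Substituent Changes on a Shared Core

The compounds below may be only part of what the source reports. "The series", "measured", "known", "first", "only" and "open" are said of these compounds alone.

compound 1 `O=C(/C=C\Nc1ccc(F)cc1)c1cn(-c2ccccc2)nc1-c1ccccc1` — 6870 nM
compound 2 `O=C(/C=C\Nc1ccc(C(F)(F)F)cc1)c1cn(-c2ccccc2)nc1-c1ccccc1` — > 50000 nM
compound 3 `O=C(/C=C\Nc1ccc(F)cc1)c1cn(-c2ccccc2)nc1-c1ccc(Cl)cc1` — > 50000 nM

In a functional assay on HT-29 cells (Homo sapiens) for antiproliferative activity, read by MTT assay, with a stated time of 48 h (on this read-out lower numbers stand for stronger inhibition and higher numbers for weaker inhibition), compound 1 gives 6870 nM. For compound 2 this assay reports only a limit, > 50000 nM. For compound 3 it likewise reports only a limit, > 50000 nM. Compound 3 therefore stands at the limit of > 50000 nM in this assay, at which 2 of the 3 values shown sit, and no number is known for it. Compound 4 `O=C(/C=C\Nc1ccc(C(F)(F)F)cc1)c1cn(-c2ccccc2)nc1-c1ccc(Cl)cc1` differs from compound 3 by trifluoromethyl in place of fluoro on an aromatic carbon. For the measured compounds named here, two measured steps bear on this. The same change, made on compound 1, gave an at least 7.2-fold higher number from compound 1 to compound 2 (0.86 log units; beyond the scatter). The change that leads to compound 3 gave an at least 7.2-fold higher number from compound 1 to compound 3 (0.86 log units; beyond the scatter). Both steps moved the number upward and beyond the scatter, and compound 3 already sits at the limit. Compound 4, which carries both changes, is therefore expected to stay at or beyond the limit, and the expected step is a step that the limit leaves unreadable from compound 3 to compound 4. In this assay compound 4 is estimated at 100000 nM, with a range from 50000 nM to 300000 nM.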

Compound 4, half-maximal inhibitory concentration: > 50000 nM
Compound 4 was reported as a limit (the forecaster's own chance of this, stated with the estimate: 90%); the middle value does not contradict the limit.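

Compound 4 sits at the same limit as compound 2 and compound 3, so neither the step from compound 3 to compound 4 nor the step from compound 2 to compound 4 can be read: the limit of > 50000 nM in this assay, at which 3 of the 4 values shown sit. The compounds shown leave open what numbers compound 2, compound 3 and compound 4 actually have, and so whether the two changes together differ from either one alone.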